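Two Close Values and an Untested Aryl Ketone

A few compounds are considered here, and "the series" means these few. Any claim that something is new, unique, unknown or untested is made for them only; others in the source may bear on it.

Measured in a functional assay on B16-F10 cells (Mus musculus) for antiproliferative activity, read by MTT assay, with a stated time of 48 h; on this read-out higher numbers stand for weaker inhibition and lower numbers for stronger inhibition:
Compound 1 `CCCC(C)Oc1ccc(C(=O)/C=C/c2c(/C=C/c3ccc(OC)cc3)cc(OC)cc2OC)cc1`: 6.7 ug/mL
Compound 2 `COc1ccc(/C=C/c2cc(OC)cc(OC)c2/C=C/C(=O)c2ccc(F)cc2)cc1`: 5.3 ug/mL

In this assay, compound 2 gives 5.3 ug/mL. This cannot be told apart from compound 1 at 6.7 ug/mL, so the two stand level. Compound 3 `COc1ccc(/C=C/c2cc(OC)cc(OC)c2/C=C/C(=O)c2ccccc2C)cc1` has not yet been measured. It differs from compound 2 as follows: 2-methylphenyl in place of 4-fluorophenyl on a carbonyl carbon. In words, 2-methylphenyl stands in place of 4-fluorophenyl on a carbonyl carbon. Among the compounds with values here, only one measured step bears on this change: a 1.3-fold lower number from compound 1 to compound 2 (0.10 log units; within the scatter). That step also altered a group on the aromatic ring held by the carbonyl, and it stayed within the scatter. Within the data shown here, no measured compound carries 2-methylphenyl, so the evidence is thin, and no shift beyond the scatter is expected. The expected step is a 1.1-fold higher number from compound 2 to compound 3 (0.05 log units; within the scatter). For compound 3 the estimated value is 6 ug/mL, with an expected range from 2.5 ug/mL to 14 ug/mL.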

Compound 3, half-maximal inhibitory concentration: 6.1 ug/mL
For compound 3 the middle estimate is 1.0-fold (0.01 log units) below the measured one; low and high end bracket the measured number.
By their numbers in this assay, from the lowest: compounds 2, 3 and 1 (each within the scatter of the next).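

In this assay the 2-methylphenyl group on a carbonyl carbon gives a 1.2-fold higher number from compound 2 to compound 3 (0.06 log units; within the scatter) when it replaces 4-fluorophenyl, and a 1.1-fold lower number from compound 1 to compound 3 (0.04 log units; within the scatter) when it replaces 4-(1-methylbutoxy)phenyl. Compounds 1, 2 and 3 therefore stand level, and this read-out does not separate the three different groups at this place, including 2-methylphenyl, which carries no fluorine and no ether oxygen. No measurement at hand offers an explanation for this level standing.

The compounds shown leave open whether any group on this carbonyl carbon can move the number beyond the scatter; a phenyl ring bearing an amine or a carboxylic acid is not among them. They also leave open what a change elsewhere would do: all three carry the shared core unchanged.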